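Moving the nitro group: working notes on compounds 1 to 4

The source may report more compounds than this note shows. Statements on the series, on what has been measured and on what is new or still open speak of the compounds shown alone.

Three compounds have been measured in a functional assay on A549 cells (Homo sapiens) for inhibition, read by MTT assay, with a stated time of 48 h; on this read-out lower numbers stand for stronger inhibition and higher numbers for weaker inhibition:

compound 1 `CCOC(=O)c1cc(-c2ccc(Cl)cc2)nn1CC(O)COc1ccc([N+](=O)[O-])cc1` gives 45000 nM
compound 2 `CCOC(=O)c1cc(-c2ccc(Cl)cc2)nn1CC(O)COc1ccccc1[N+](=O)[O-]` gives 26000 nM
compound 3 `CCOC(=O)c1cc(-c2ccc(OC)cc2)nn1CC(O)COc1ccc([N+](=O)[O-])cc1` gives 44000 nM

Compound 1 and compound 2 differ in one place, (2-nitrophenyl in place of 4-nitrophenyl on an oxygen on a saturated carbon), and the step in this assay is a 1.7-fold lower number from compound 1 to compound 2 (0.24 log units; within the scatter). Compound 1 and compound 3 differ in one place as well, (methoxy in place of chloro on an aromatic carbon), with a step of a 1.0-fold lower number from compound 1 to compound 3 (0.01 log units; within the scatter). Compound 3 stands beside compound 1 and compound 2 with all three numbers within the scatter of one another, so no order among them can be read from these data.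

Compound 4 `CCOC(=O)c1cc(-c2ccc(OC)cc2)nn1CC(O)COc1ccccc1[N+](=O)[O-]` has not yet been measured. It differs from compound 3 by 2-nitrophenyl in place of 4-nitrophenyl on an oxygen on a saturated carbon, which is the same change as that from compound 1 to compound 2, occurring twice among these four compounds and at the same place in both pairs. The two cores on which the change is made differ by methoxy in place of chloro on an aromatic carbon.

Among the measured compounds shown here, for compound 4 in this assay a step of a 1.6-fold lower number from compound 3 to compound 4 (0.21 log units; within the scatter) is expected, set beside a 1.7-fold lower number from compound 1 to compound 2 (0.24 log units; within the scatter), resting on the single earlier instance of this change between compound 1 and compound 2 and on the within-scatter step between compound 1 and compound 3. Compound 4 is accordingly estimated at 27000 nM, with the likely range running from 13000 nM to 56000 nM.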

Compound 4, half-maximal inhibitory concentration: 45000 nM
Estimate against measurement, compound 4: 1.7-fold (0.22 log units) below, within the range that was stated.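

The change of 2-nitrophenyl for 4-nitrophenyl gives a 1.0-fold higher number from compound 3 to compound 4 (0.01 log units; within the scatter) in this assay, and its size on the two cores cannot be told apart: the same change on two cores in this assay, a 1.7-fold lower number (0.24 log units; within the scatter) from compound 1 to compound 2 and a 1.0-fold higher number (0.01 log units; within the scatter) from compound 3 to compound 4, 1.8-fold (0.25 log units) apart, within the scatter of two such steps. The change of methoxy for chloro, made on the 2-nitrophenyl compounds, gives a 1.7-fold higher number from compound 2 to compound 4 (0.24 log units; within the scatter) and reads the same way when set beside its earlier instance: the same change on two cores in this assay, a 1.0-fold lower number (0.01 log units; within the scatter) from compound 1 to compound 3 and a 1.7-fold higher number (0.24 log units; within the scatter) from compound 2 to compound 4, 1.8-fold (0.25 log units) apart, within the scatter of two such steps. Every step among these four compounds lies within the scatter, so the data are consistent with either change carrying from one core to the other, but they do not show that either change alters the number at all, nor that it would carry over once a step of real size is in play.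

Still open, from the compounds shown here alone, is whether any change on this series gives a step beyond the scatter, since the four compounds vary only in where the nitro group sits and in chloro or methoxy, and all keep the ethyl ester and the chain bearing the hydroxyl. An amine in place of the nitro group, a carboxylic acid in place of the ethyl ester, or a longer chain in place of the one bearing the hydroxyl would be the next points of comparison in this assay.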